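A few compounds are considered here, and "the series" means these few. Any claim that something is new, unique, unknown or untested is made for them only; others in the source may bear on it.

In an ADME assay on microsomes from liver (Rattus norvegicus), read by LC-MS, with a stated time of 90 min (on this read-out higher numbers stand for higher hepatic extraction and lower numbers for lower hepatic extraction), compound 2 `CCC(CC)n1c(=O)[nH]c2ncc(OC)nc21` gives > 0.7, which is a limit of the assay and not a number. In this assay compound 1 `CCC(CC)n1c(=O)[nH]c2ncc(C(F)(F)F)nc21` gives 0.2. Going by the values given here, the one measured step, a number at least 0.50 higher from compound 1 to compound 2 (beyond the scatter), runs up against that limit (the limit of > 0.7 in this assay, at which 1 of the 2 values shown sits). Compound 3 `C=Cc1cnc2[nH]c(=O)n(C(CC)CC)c2n1` differs from compound 2 by vinyl in place of methoxy on an aromatic carbon. That measured step swapped a different group, so it bears only loosely on this change; with compound 2 at the limit, a downward step of modest size, a number at least 0.10 lower from compound 2 to compound 3 (that floor lies within the scatter), is expected. Compound 3 is therefore estimated at 0.6, between 0.35 and 0.85.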

Compound 3, hepatic extraction ratio: > 0.7
Compound 3: no number, only a limit; the forecaster's own chance of this, stated with the estimate: 40%; middle value at least 0.10 from the limit.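

In this assay compound 3 gives > 0.7, which is a limit of the assay and not a number. Vinyl in place of trifluoromethyl on this aromatic carbon gives a number at least 0.50 higher from compound 1 to compound 3 (beyond the scatter), so a second replacement, not only methoxy, stands well clear of compound 1. The step from compound 2 to compound 3 cannot be read, since both sit at the same limit: the limit of > 0.7 in this assay, at which 2 of the 3 values shown sit.

As far as these compounds go, how far compound 2 and compound 3 lie past that limit stays open, and so does any order between methoxy and vinyl. Where an amine or a longer chain at this carbon would fall also stays open.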